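A methyl added where no number can be read

This account rests on a few compounds, and the source may have more. Where it says the series, first, only, none or still open, it means among the compounds named here.

Three compounds sharing one core were tested in a physicochemical assay for solubility, in phosphate buffer, at pH 7.4 (a lower number here means a less soluble compound, a higher number a more soluble compound), and none gave an exact number. Compound 1 (`CCOC(=O)c1c(-c2ccccc2C)[nH]c2cc(OC)ccc2c1=O`) gives > 100000 nM as a limit of the assay. Compound 2 (`CCOC(=O)c1c(-c2cccc(F)c2)[nH]c2cc(OC)ccc2c1=O`) gives > 100000 nM as a limit too. Compound 3 (`CCOC(=O)c1c(-c2ccccc2)[nH]c2cc(OC)ccc2c1=O`) gives > 100000 nM as a limit as well. Compound 3 therefore stands only at the limit of > 100000 nM in this assay, at which 3 of the 3 values shown sit, and has no exact figure.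

The next structure is compound 4 (`CCOC(=O)c1c(-c2cccc(C)c2)[nH]c2cc(OC)ccc2c1=O`), which has methyl in place of hydrogen on an aromatic carbon, meta to a large group, so that phenyl becomes 3-methylphenyl (methyl in place of hydrogen on an aromatic carbon). Three measured steps come close to this change. Hydrogen in place of methyl gives a step that the two limits leave unreadable from compound 1 to compound 3 and hydrogen in place of fluoro gives a step that the two limits leave unreadable from compound 2 to compound 3 in the same assay. Swapping one substituted phenyl for the other gives a step that the two limits leave unreadable from compound 1 to compound 2 as well. None of these sizes can be read, so they point in no direction, and no shift beyond the usual scatter is expected in this assay for the added methyl. The expected change, an estimate only, is a number no higher from compound 3 to compound 4 (the limit leaves the size open) and carries no direction. Compound 4 will most likely again return only a limit, and its estimated value is 100000 nM (expected range 50000 nM to 200000 nM).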

Compound 4, solubility: 48000 nM
Estimate against measurement, compound 4: 2.1-fold (0.32 log units) above, outside the stated range (below it).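

In this assay, among the compounds shown here, compound 4 gives 48000 nM, the first exact number in this set. It shows that a single methyl on an aromatic carbon, meta to a large group, can bring the read-out down from the limit. Set against the parent phenyl, the change gives an at least 2.0-fold lower number from compound 3 to compound 4 (0.31 log units; beyond the scatter); set against the fluoro analogue it gives an at least 2.0-fold lower number from compound 2 to compound 4 (0.31 log units; beyond the scatter), and the place of the methyl counts too, with 3-methylphenyl in place of 2-methylphenyl giving an at least 2.0-fold lower number from compound 1 to compound 4 (0.31 log units; beyond the scatter). These sizes are minimums, and the steps among compound 1, compound 2 and compound 3 still cannot be read, because all three of those compounds stand at a limit: the limit of > 100000 nM in this assay, at which 3 of the 4 values shown sit.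

The compounds shown leave open whether a longer chain such as ethyl, or an amine or a carboxylic acid, at this same place would push the number further down or return it to the limit. From the compounds shown here alone, the true size of the methyl step also stays open: of the four compounds, only compound 4 carries an exact figure.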